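Swapping fluorine positions on the benzylidene ring

This account rests on a few compounds, and the source may have more. Where it says the series, first, only, none or still open, it means among the compounds named here.

Compounds measured so far:
Compound 1, `CCN(CC)CCCn1c(=O)c(=Cc2ccc(F)cc2F)s/c1=C1\C(=O)Nc2ccc(Cl)cc21`, in a functional assay on MDA-MB-231 cells (Homo sapiens) for inhibition, read by MTT assay, with a stated time of 72 h (a higher number here means a weaker inhibitor, a lower number a stronger inhibitor), gives > 200000 nM, which is a limit of the assay and not a number.
Compound 2, `CCN(CC)CCCn1c(=O)c(=Cc2ccc(F)c(F)c2)s/c1=C1\C(=O)Nc2cc(F)ccc21`, gives 2900 nM in this assay.
Compound 3, `COc1cc(C=c2s/c(=C3\C(=O)Nc4ccc(F)cc43)n(CCN(C)C)c2=O)cc(OC)c1OC`, gives 1900 nM in this assay.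

Compound 2 holds the higher of the two numbers that were actually read, though its gap to compound 3 lies within the scatter, so the two cannot be placed in order. Among the measured compounds shown here, compound 1 differs from compound 2 in two places at once and no single step can be drawn from it.

The next compound, compound 4, `CCN(CC)CCCn1c(=O)c(=Cc2ccc(F)cc2F)s/c1=C1\C(=O)Nc2cc(F)ccc21`, is compound 2 with one change (2,4-difluorophenyl in place of 3,4-difluorophenyl on a double-bonded chain carbon bound to an aromatic carbon). This is the same 2,4-difluorophenyl that compound 1 carries, while the rest of compound 4 is the core of compound 2.

For the measured compounds named here, the only compound bearing the 2,4-difluorophenyl, compound 1, reached the limit of the assay, whereas the two compounds with other aryl groups gave numbers. The expected step of a 5.2-fold higher number from compound 2 to compound 4 (0.71 log units; beyond the scatter) is therefore towards weaker inhibition, likely beyond the scatter, though with considerable uncertainty since compound 1 also differs in its halogen. Compound 4 is estimated to give 15000 nM, with a range from 3000 nM to 120000 nM.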

Compound 4, half-maximal inhibitory concentration: 2100 nM
Beside the measured number, compound 4's estimate is 7.1-fold (0.85 log units) above it; measured number outside the range, below it.
By their numbers in this assay, from the lowest: compounds 3, 4 and 2 (each within the scatter of the next). At a limit, above all of these: compound 1.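

In this assay, putting 2,4-difluorophenyl in place of 3,4-difluorophenyl on a double-bonded chain carbon bound to an aromatic carbon gives a 1.4-fold lower number from compound 2 to compound 4 (0.14 log units; within the scatter), so on the core of compound 2 the two fluorine patterns cannot be told apart. Compound 4 carries the same 2,4-difluorophenyl as compound 1 and still gives a readable number, so this group alone does not bring a value to the limit of the assay. Compound 1 alone stands at such a limit, which is not a number: the limit of > 200000 nM in this assay, at which 1 of the 4 values shown sits.

From the compounds shown here alone, compound 1 carries a chlorine on the shared core where compound 4 carries a fluorine, but the steps to compound 1 cannot be read, so what that difference contributes remains unknown. Going by these compounds, it also remains open whether this aryl position accepts anything other than fluorine on the phenyl ring, such as an amine or a carboxylic acid, and whether a plain phenyl with no fluorine at all would give a number within the scatter of compound 2.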